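This account rests on a few compounds, and the source may have more. Where it says the series, first, only, none or still open, it means among the compounds named here.

For the measured compounds named here, compound 2 `C[C@H](NC(=O)c1c(C2CCC2)nnn1Cc1ccc(C(F)(F)F)cc1)c1ccc(C(=O)O)cc1` gives 75.3 nM in a functional assay on CHO cells for antagonist activity at prostaglandin E2 receptor EP4 subtype (Homo sapiens), read by calcium flux, with a stated time of 15 min (on this read-out higher numbers stand for weaker inhibition and lower numbers for stronger inhibition), and this is the only number among the values shown. Compound 1 `CCc1nnn(Cc2ccc(C(F)(F)F)cc2)c1C(=O)N[C@@H](C)c1ccc(C(=O)O)cc1` gives only a limit of the assay, > 10000 nM, in this assay. Going by the values given here, the one measured change, an at least 130-fold lower number from compound 1 to compound 2 (2.12 log units; beyond the scatter), is large and came from replacing ethyl with cyclobutyl. Compound 3 `C[C@H](NC(=O)c1c(C2CCCC2)nnn1Cc1ccc(C(F)(F)F)cc1)c1ccc(C(=O)O)cc1` differs from compound 2 by cyclopentyl in place of cyclobutyl on an aromatic carbon. Going from one ring to a slightly bigger ring has no measured precedent here, so only a modest step is expected, a 1.5-fold lower number from compound 2 to compound 3 (0.18 log units; within the scatter), with the direction uncertain. Compound 3 is therefore expected to give 50 nM, between 10 nM and 300 nM.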

Compound 3, half-maximal inhibitory concentration: 65.1 nM
Compound 3: the middle estimate sits 1.3-fold (0.11 log units) below what was measured, and the stated range covers the measured number.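

In this assay, widening the ring from cyclobutyl to cyclopentyl on this aromatic carbon makes no clear difference, with a 1.2-fold lower number from compound 2 to compound 3 (0.06 log units; within the scatter). Replacing ethyl with cyclopentyl gives an at least 150-fold lower number from compound 1 to compound 3 (2.18 log units; beyond the scatter), so the large step seen with cyclobutyl is shared by both of these rings. Compound 1 gives a limit of the assay, not a number: the limit of > 10000 nM in this assay, at which 1 of the 3 values shown sits.

Still open, going by these compounds, is how this position responds to cyclopropyl, to cyclohexyl or to an open branched chain such as isopropyl, and whether a ring containing oxygen, such as tetrahydropyranyl, would fit here.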